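The source may report more compounds than this note shows. Statements on the series, on what has been measured and on what is new or still open speak of the compounds shown alone.

Among the compounds with values here, in an ADME assay on MT4 cells (Homo sapiens) for cytotoxicity, read by MTT assay, with a stated time of 96 h (a lower number here means that less compound is tolerated, a higher number that more compound is tolerated), the entry for compound 1 `COc1ccc(-c2nc3cc(/C(C)=N/NC(N)=O)ccc3n2C2CCCCC2)cc1` reads "not determined" (no result reported), so only two numbers exist. Compound 2 `C/C(=N\NC(N)=S)c1ccc2c(c1)nc(-c1ccc(Cl)cc1)n2C1CCCCC1` gives 17000 nM and compound 3 `C/C(=N\NC(N)=S)c1ccc2c(c1)nc(-c1ccc(C(F)(F)F)cc1)n2C1CCCCC1` gives 30000 nM, which places compound 3 within the scatter of compound 2. Compound 4 `COc1ccc(-c2nc3cc(/C(C)=N/NC(N)=S)ccc3n2C2CCCCC2)cc1` has not been measured and differs from compound 3 by methoxy in place of trifluoromethyl on an aromatic carbon. Within the data shown here, the only measured change at that carbon, trifluoromethyl in place of chloro, was a 1.8-fold higher number from compound 2 to compound 3 (0.25 log units; within the scatter). Compound 1 also carries methoxy but offers no number. No shift beyond the scatter is therefore expected in this assay, and a 1.4-fold lower number from compound 3 to compound 4 (0.13 log units; within the scatter) is the expected step. For compound 4 the estimated value is 22000 nM, with an expected range from 9000 nM to 50000 nM.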

Compound 4, half-maximal cytotoxic concentration: 39000 nM
Compound 4: middle estimate off by 1.8-fold (0.25 log units), on the low side; low and high end bracket the measured number.
By their numbers in this assay, from the lowest: compounds 2, 3 and 4 (each within the scatter of the next, the first and the last beyond it).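

In this assay, methoxy in place of trifluoromethyl at this carbon stays within the scatter (a 1.3-fold higher number from compound 3 to compound 4 (0.11 log units; within the scatter)). Methoxy in place of chloro, however, gives the first step at this position to clear the scatter (a 2.3-fold higher number from compound 2 to compound 4 (0.36 log units; beyond the scatter)), though only modestly. The three groups thus span a narrow range, with only chloro and methoxy lying beyond the scatter of each other, and no measurement here bears on the reason. On these data alone, whether an amine, a carboxylic acid or a longer chain on this carbon would stay within that range remains open.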